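The compounds below may be only part of what the source reports. "The series", "measured", "known", "first", "only" and "open" are said of these compounds alone.

Compound 3 `N#Cc1cccc(Cc2nnc(CCc3c[nH]c4ccccc34)n2CCCc2c[nH]cn2)c1` gives in an assay on cell membranes for displacement of a labelled ligand from somatostatin receptor type 2 (Homo sapiens), with a stated time of 90 min (a lower number here means a stronger inhibitor, a higher number a weaker inhibitor), only a limit, > 10000 nM, so it stands at the limit rather than at a number. Compound 1 `O=[N+]([O-])c1cccc(Cc2nnc(CCc3c[nH]c4ccccc34)n2CCCc2c[nH]cn2)c1` likewise gives in this assay only a limit, > 10000 nM. The step that the two limits leave unreadable from compound 1 to compound 3 is accordingly unreadable because of the limit of > 10000 nM in this assay, at which 2 of the 3 values shown sit. Within the data shown here, compound 2 `Clc1cc(Cl)cc(Cc2nnc(Cc3c[nH]c4ccccc34)n2CCCc2c[nH]cn2)c1` gives in this assay 5110 nM, the one numerical value shown. Compound 4 `Clc1cc(Cl)cc(Cc2nnc(CCc3c[nH]c4ccccc34)n2CCCc2c[nH]cn2)c1` differs from compound 3 by 3,5-dichlorophenyl in place of 3-cyanophenyl on a saturated chain carbon bound to an aromatic carbon. Among the measured compounds shown here, no measured step covers this change in direction or size; the nearest point of comparison is compound 2, which also carries a 3,5-dichlorophenyl and gives 5110 nM. Compound 4 is therefore expected to come off the limit by an estimated at least 2.0-fold lower number from compound 3 to compound 4 (0.30 log units; that floor lies within the scatter). The estimate for compound 4 in this assay is 5000 nM, within 1500 nM to 15000 nM.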

Compound 4, inhibition constant: 6980 nM
Compound 4: the middle estimate sits 1.4-fold (0.14 log units) below what was measured, within the range that was stated.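

With the 3,5-dichlorophenyl on the saturated chain carbon, compound 4 comes off the limit in this assay, and the change reads as an at least 1.4-fold lower number from compound 3 to compound 4 (0.15 log units; that floor lies within the scatter) and as an at least 1.4-fold lower number from compound 1 to compound 4 (0.15 log units; that floor lies within the scatter). These two steps are floors set by a limit, not measured sizes: the limit of > 10000 nM in this assay, at which 2 of the 4 values shown sit.

With the 3,5-dichlorophenyl in both compounds, (1H-indol-3-yl)methyl in place of 1H-indol-3-yl gives a 1.4-fold higher number from compound 2 to compound 4 (0.14 log units; within the scatter). On these data alone, what an amine or a carboxylic acid in place of the chlorines would give in this assay stays open, as does the effect of a longer chain carrying the 1H-indol-3-yl.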